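The source may hold more compounds than are shown below. What is called first, only, known or untested is meant among the compounds shown, and "the series" means these compounds.

Measured compounds:
Compound 1 `Cc1cc(O)c(C2=NN(c3ccc(S(N)(=O)=O)cc3)C(c3ccccc3O)C2)cc1Cl` — in a functional assay on SR cells (Homo sapiens) for antiproliferative activity, with a stated time of 48 h (a higher number here means that more compound is tolerated, a lower number that less compound is tolerated), compound 1 gives > 100000 nM, which is a limit of the assay rather than a number.
Compound 2 `Cc1cc(O)c(C2=NN(c3ccc(S(N)(=O)=O)cc3)C(c3ccccc3Cl)C2)cc1Cl` — in this assay compound 2 gives > 100000 nM, again a limit rather than a number.
Compound 3 `Cc1cc(O)c(C2=NN(c3ccc(S(N)(=O)=O)cc3)C(/C=C/c3ccccc3)C2)cc1Cl` — in this assay compound 3 gives 89700 nM.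

Compound 2 thus stands only at the limit of > 100000 nM in this assay, at which 2 of the 3 values shown sit, with no number of its own. Compound 4 `COc1ccc(C2CC(c3cc(Cl)c(C)cc3O)=NN2c2ccc(S(N)(=O)=O)cc2)c(OC)c1OC` differs from compound 2 in one place: 2,3,4-trimethoxyphenyl in place of 2-chlorophenyl on a saturated ring carbon. Within the data shown here, no measured step exchanges the group on that saturated ring carbon for a 2,3,4-trimethoxyphenyl; the nearest steps are an at least 1.1-fold lower number from compound 2 to compound 3 (0.04 log units; that floor lies within the scatter) and an at least 1.1-fold lower number from compound 1 to compound 3 (0.04 log units; that floor lies within the scatter), both floors lying within the scatter, and a step that the two limits leave unreadable from compound 1 to compound 2 gives no size at all. Every measured value sits at or close to the limit, so no step beyond the scatter is expected in this assay. Compound 4 is therefore estimated at 100000 nM, within a range from 35000 nM to 300000 nM, meaning an expected a number no higher from compound 2 to compound 4 (the limit leaves the size open).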

Compound 4, concentration lethal to 50% of the cells: > 100000 nM
Compound 4: a limit, no number; the forecaster's own chance of this, stated with the estimate: 60%; the middle value sits exactly at the limit.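

On this saturated ring carbon, 2,3,4-trimethoxyphenyl, which brings hydrogen-bond acceptors that 2-chlorophenyl lacks, still leaves the result in this assay at the assay limit: the limit of > 100000 nM in this assay, at which 3 of the 4 values shown sit.
The steps from compound 1 and compound 2 to compound 4 cannot be read, and the only readable one is an at least 1.1-fold higher number from compound 3 to compound 4 (0.04 log units; that floor lies within the scatter). No group shown here at this position moves the number clear of the limit.
Going by these compounds, whether an amine, a carboxylic acid or a longer alkyl chain on this carbon would do so stays open. So does the effect of replacing the 4-sulfamoylphenyl group.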